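Swapping benzyl for tert-butyl on a nitrone: two related pairs

The source may report more compounds than this note shows. Statements on the series, on what has been measured and on what is new or still open speak of the compounds shown alone.

Four compounds share a triazole bearing a nitrone arm, and differ in two places: the group on the triazole nitrogen and the group on the nitrone nitrogen. Compound 1 `[O-]/[N+](=C\c1cn(-c2ccc(C(F)(F)F)cc2)nn1)Cc1ccccc1` carries benzyl on that nitrogen, and compound 3 `CC(C)(C)/[N+]([O-])=C/c1cn(-c2ccc(C(F)(F)F)cc2)nn1` carries tert-butyl there; the change from one to the other is tert-butyl in place of benzyl on a double-bonded nitrogen. Compound 2 `CCCCCCCCn1cc(/C=[N+](\[O-])Cc2ccccc2)nn1` again has benzyl, while its unmeasured partner compound 4 `CCCCCCCCn1cc(/C=[N+](\[O-])C(C)(C)C)nn1` has tert-butyl; the change is tert-butyl in place of benzyl on a double-bonded nitrogen, the same change made on a different core. How the core of compound 1 differs from the core of compound 2 is not broken down here.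

In a functional assay on PC-3 cells (Homo sapiens) for inhibition, read by MTT assay, with a stated time of 24 h (a higher number here means a weaker inhibitor, a lower number a stronger inhibitor), compound 1 reaches only a limit, > 100000 nM, and that is a limit of the assay, not a number, a point noted in the limit of > 100000 nM in this assay, at which 2 of the 3 values shown sit. Compound 2 likewise gives only a limit in this assay, > 100000 nM. Compound 3 gives a measured number in this assay, 42000 nM. Putting benzyl against tert-butyl on the first core gives an at least 2.3-fold lower number from compound 1 to compound 3 (0.37 log units; beyond the scatter).

Compound 4 is expected to move in the same direction, so that the estimated step of an at least 1.6-fold lower number from compound 2 to compound 4 (0.22 log units; that floor lies within the scatter) follows the earlier one, because compound 3 gave 42000 nM. Since the starting point for compound 2 is itself a limit, the expected value for compound 4 is 60000 nM, with a range from 20000 nM to 150000 nM, and a real chance that this assay again reports only a limit.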

Compound 4, half-maximal inhibitory concentration: 24600 nM
Estimate against measurement, compound 4: 2.4-fold (0.39 log units) above; low and high end bracket the measured number.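

In this assay, putting tert-butyl in place of benzyl on a double-bonded nitrogen gives an at least 4.0-fold lower number from compound 2 to compound 4 (0.60 log units; beyond the scatter), so on this second core the change points the same way as it did on the first. As far as these compounds go, compound 2 gives > 100000 nM, which is a limit of the assay and not a number, so the true size of this step stays unknown and the printed size is only a floor. The direction therefore carries over in both pairs, with no pair going against it, but these data do not show that the change is worth the same amount on each core, and two cores are too few to make it a rule for the series: the same change on two cores in this assay, an at least 2.3-fold lower number (0.37 log units; beyond the scatter) from compound 1 to compound 3 and an at least 4.0-fold lower number (0.60 log units; beyond the scatter) from compound 2 to compound 4; the limit leaves it open whether they differ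

The compounds shown leave open whether other small groups on that nitrogen, such as methyl or isopropyl, would also give measurable numbers where benzyl gives only a limit, or whether the gain belongs to tert-butyl alone. They also leave open whether the change would hold on further cores, for instance with a shorter chain such as butyl on the triazole nitrogen in place of the octyl chain.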